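A few compounds are considered here, and "the series" means these few. Any claim that something is new, unique, unknown or untested is made for them only; others in the source may bear on it.

Measured compounds:
Compound 1, `Nc1ccccc1/C=C/c1ccccc1O`: 36 ug/mL
Compound 2, `COc1ccccc1/C=C/c1ccccc1O`: 23 ug/mL
Compound 3, `Nc1cccc(/C=C/c2ccccc2O)c1`: 30.4 ug/mL

These three values come from a functional assay on HT-29 cells (Homo sapiens) for inhibition, read by MTT assay, with a stated time of 2 days; a lower number here means a stronger inhibitor, a higher number a weaker inhibitor. Compound 4, `COc1cccc(/C=C/c2ccccc2O)c1`, has not yet been measured there. It differs from compound 3 by methoxy in place of amino on an aromatic carbon. The same kind of change separates compound 1 from compound 2, namely (methoxy in place of amino on an aromatic carbon), and in that pair it gave a 1.6-fold lower number from compound 1 to compound 2 (0.19 log units; within the scatter). The two changes are not the same: in one the place is "ortho to a group of 9 heavy atoms", in the other "meta to a group of 9 heavy atoms". The difference between the cores of compound 1 and compound 3 is not broken down here. Because the earlier step was a 1.6-fold lower number from compound 1 to compound 2 (0.19 log units; within the scatter), the step from compound 3 to compound 4 in this assay is expected to be similar, a 1.4-fold lower number from compound 3 to compound 4 (0.16 log units; within the scatter). Compound 4 is therefore estimated at 21 ug/mL, between 11 ug/mL and 40 ug/mL.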

Compound 4, half-maximal inhibitory concentration: 26 ug/mL
Beside the measured number, compound 4's estimate is 1.2-fold (0.09 log units) below it; the measured number falls inside the stated range.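

In this assay, methoxy in place of amino on an aromatic carbon, meta to a group of 9 heavy atoms, gave a 1.2-fold lower number from compound 3 to compound 4 (0.07 log units; within the scatter). Set beside the earlier pair, the change reads alike on both cores: the same change on two cores in this assay, a 1.6-fold lower number (0.19 log units; within the scatter) from compound 1 to compound 2 and a 1.2-fold lower number (0.07 log units; within the scatter) from compound 3 to compound 4, 1.3-fold (0.13 log units) apart, within the scatter of two such steps. Among these compounds, neither step lies beyond the scatter, so this agreement shows only that the swap made no measurable difference on either core; it does not show that methoxy improves on amino, and two pairs set no rule for other cores.

The compounds shown leave open how a larger step might carry across these cores. Going by these compounds, a carboxylic acid, a nitrile or a longer chain such as butoxy in the same place remains untested here.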